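Methyl on the Shared Core, Placed Differently

The compounds below may be only part of what the source reports. "The series", "measured", "known", "first", "only" and "open" are said of these compounds alone.

Going by the values given here, compound 1 `O=C1NCCN1CCN1CCC(n2cc(-c3ccc(F)cc3)c3ccccc32)CC1` carries the lowest of the two numbers measured so far in an assay on cell membranes for displacement of a labelled ligand from Alpha-1A adrenergic receptor (Rattus norvegicus) (on this read-out lower numbers stand for stronger inhibition and higher numbers for weaker inhibition), where compound 1 gives 6.3 nM. Its nearest neighbour is compound 2 `Cc1cccc2c1c(-c1ccc(F)cc1)cn2C1CCN(CCN2CCNC2=O)CC1`, which in this assay gives 34 nM; the step of a 5.4-fold higher number from compound 1 to compound 2 (0.73 log units; beyond the scatter) came with a methyl in place of hydrogen on an aromatic carbon. Compound 3 `Cc1cccc2c(-c3ccc(F)cc3)cn(C3CCN(CCN4CCNC4=O)CC3)c12` differs from compound 1 by methyl in place of hydrogen on an aromatic carbon, the methyl entering a six-membered aromatic ring of carbon only, part of a fused system of two rings, ortho to a fused ring. Among the compounds with values here, the only measured step that bears on this change is the one in which a methyl also replaced a hydrogen on an aromatic carbon of the shared core, and there a 5.4-fold higher number from compound 1 to compound 2 (0.73 log units; beyond the scatter) was seen. A weakening of similar or somewhat smaller size is therefore expected, giving an estimated step of a 2.5-fold higher number from compound 1 to compound 3 (0.40 log units; beyond the scatter). Compound 3 is expected to give about 16 nM, within a range from 5 nM to 50 nM.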

Compound 3, half-maximal inhibitory concentration: 23 nM
Compound 3: middle estimate off by 1.4-fold (0.16 log units), on the low side, and the stated range covers the measured number.
By their numbers in this assay, from the lowest: compound 1; then compounds 3 and 2 (each within the scatter of the next).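

In this assay, the methyl on an aromatic carbon of the six-membered aromatic ring, ortho to a fused ring, brings a 3.7-fold higher number from compound 1 to compound 3 (0.56 log units; beyond the scatter). The higher number is therefore not confined to one placement: the other methyl placement on the shared core brought a 5.4-fold higher number from compound 1 to compound 2 (0.73 log units; beyond the scatter), so both steps run the same way and both lie beyond the scatter, with neither listed compound going against this. Nothing measured here gives a reason for either rise.

As far as these compounds go, whether a fluorine, a hydroxyl group, an amine or a longer chain such as ethyl on this same carbon would move the number as the methyl does remains open. The compounds shown also leave open whether the methyl step would keep its size on a core carrying a different group in place of the fluorophenyl.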